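This account rests on a few compounds, and the source may have more. Where it says the series, first, only, none or still open, it means among the compounds named here.

Compound 1, with the structure `COc1cc2c(cc1OC)C(c1ccccc1)=NNC(=O)C2`, is the starting point of this small series. In a functional assay on the whole organism with Mus musculus as the target (on this read-out lower numbers stand for an effect already at smaller amounts and higher numbers for an effect only at larger amounts of compound), compound 1 gives 33.9 umol/kg. Compound 2, with the structure `COc1cc2c(cc1OC)C(c1ccc(N)cc1)=NNC(=O)C2`, carries one change relative to compound 1, namely (amino in place of hydrogen on an aromatic carbon). In this assay compound 2 gives 15 umol/kg, so that the change brought a 2.3-fold lower number from compound 1 to compound 2 (0.35 log units; beyond the scatter).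

Compound 3, with the structure `COc1cc2c(cc1OC)C(c1ccccc1)=NN(C)C(=S)C2`, has a different core from compound 1; the difference between the two cores is not broken down here. In this assay compound 3 gives 30.6 umol/kg, a value that sits within the usual scatter of that of compound 1, so the two cannot be told apart on this read-out.

Compound 4, with the structure `COc1cc2c(cc1OC)C(c1ccc(N)cc1)=NN(C)C(=S)C2`, has not yet been measured. It differs from compound 3 by amino in place of hydrogen on an aromatic carbon, which is the same change that turned compound 1 into compound 2, made at the same place. Given the step seen from compound 1 to compound 2, namely a 2.3-fold lower number from compound 1 to compound 2 (0.35 log units; beyond the scatter), the step from compound 3 to compound 4 is expected to be of similar size, about a 2.2-fold lower number from compound 3 to compound 4 (0.34 log units; beyond the scatter). On that basis compound 4 is expected to give about 14 umol/kg in this assay. Allowing for the usual scatter of repeated measurements, the value for compound 4 is estimated to fall between 7 umol/kg and 28 umol/kg.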

Compound 4, dose for half-maximal effect: 29.8 umol/kg
The estimate for compound 4 lay 2.1-fold (0.33 log units) below the measured number; measured number above the stated range.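

On the core of compound 3, exchanging phenyl for 4-aminophenyl gives a 1.0-fold lower number from compound 3 to compound 4 (0.01 log units; within the scatter) in this assay, so compound 3 and compound 4 cannot be told apart on this read-out. On the core of compound 1, the same exchange gave a step beyond the scatter, yet set side by side the two steps cannot be separated either: the same change on two cores in this assay, a 2.3-fold lower number (0.35 log units; beyond the scatter) from compound 1 to compound 2 and a 1.0-fold lower number (0.01 log units; within the scatter) from compound 3 to compound 4, 2.2-fold (0.34 log units) apart, within the scatter of two such steps. Going by these compounds alone, this shows that the step on the core of compound 1 cannot be relied on to give a clear step on the core of compound 3, but it does not show that the two cores truly respond differently, and with only two pairs of compounds neither a shared effect nor a core-dependent one is established.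

Going by these compounds, it remains open how other groups at the same place on the phenyl ring, such as a hydroxyl or a dimethylamino group, would behave on each of the two cores. The compounds shown also leave open which part of the difference between the two cores matters, and whether the amino group gives a clear step on any further core.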